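Benzoyl in place of octylcarbonyl on the ring nitrogen

The compounds below may be only part of what the source reports. "The series", "measured", "known", "first", "only" and "open" are said of these compounds alone.

Compound 3 `CCCCCCCCC(=O)N1c2ccccc2CCC1C(=O)Nc1cc(C(F)(F)F)cc(C(F)(F)F)c1` gives the lowest of the two numbers in a functional assay on PC-3 cells (Homo sapiens) for cytotoxicity, read by sulforhodamine B assay, with a stated time of 72 h (on this read-out lower numbers stand for stronger inhibition of growth and higher numbers for weaker inhibition of growth), at 7430 nM. Compound 1 `O=C(Nc1ccc(C(F)(F)F)cc1)C1CCc2ccccc2N1` gives 20300 nM in this assay. Compound 2 `CC(=O)N1c2ccccc2CCC1C(=O)Nc1cc(C(F)(F)F)cc(C(F)(F)F)c1` sits at the limit of > 70000 nM in this assay, so no number is known for it. Within the data shown here, the one step at the same place is an at least 9.4-fold lower number from compound 2 to compound 3 (0.97 log units; beyond the scatter); it rests on (the limit of > 70000 nM in this assay, at which 1 of the 3 values shown sits). Compound 4 `O=C(Nc1cc(C(F)(F)F)cc(C(F)(F)F)c1)C1CCc2ccccc2N1C(=O)c1ccccc1` differs from compound 3 by phenyl in place of octyl on a carbonyl carbon. The hydrogen end of that measured step sat at the limit, and phenyl is a shorter group than the octyl it replaces, so a modest move back toward higher numbers is expected. Compound 4 is therefore estimated at 15000 nM, within 4000 nM to 60000 nM, an expected step of a 2.0-fold higher number from compound 3 to compound 4 (0.31 log units; beyond the scatter).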

Compound 4, concentration for 50% growth inhibition: 3500 nM
The estimate for compound 4 lay 4.3-fold (0.63 log units) above the measured number; the whole stated range lies above it.
By their numbers in this assay, from the lowest: compound 4; then compound 3; then compound 1. At a limit, above all of these: compound 2.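

At the carbonyl carbon on the ring nitrogen, phenyl goes beyond what the octyl chain reached, with a 2.1-fold lower number from compound 3 to compound 4 (0.33 log units; beyond the scatter) in this assay. A long chain is therefore not required at this place: phenyl has fewer heavy atoms than octyl and still gives the lower number. Against methyl at the same place, the change reads an at least 20-fold lower number from compound 2 to compound 4 (1.30 log units; beyond the scatter), and this step rests on a limit for compound 2: (the limit of > 70000 nM in this assay, at which 1 of the 4 values shown sits).

Open, on these data alone, is how a benzoyl bearing an amine or a carboxylic acid would read in this assay. Also open, as far as these compounds go, is whether cyclohexyl, a saturated ring, would match phenyl on this carbonyl carbon.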